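The source may hold more compounds than are shown below. What is called first, only, known or untested is meant among the compounds shown, and "the series" means these compounds.

The three measured compounds share one core and differ mainly in the aryl group attached to it. Compound 1 `COc1ccc2cc(C(C)c3nnc4n3N=C(c3ccc(C)cc3)CS4)ccc2c1` gives 10200 nM in a functional assay on HCT-116 cells (Homo sapiens) for inhibition, read by sulforhodamine B assay, with a stated time of 72 h (on this read-out higher numbers stand for weaker inhibition and lower numbers for stronger inhibition), and compound 2 `COc1ccc2cc(C(C)c3nnc4n3N=C(c3ccc([N+](=O)[O-])cc3)CS4)ccc2c1`, which carries a nitro group in place of the methyl on that aryl ring, gives 15100 nM in this assay, so that a 1.5-fold higher number from compound 1 to compound 2 (0.17 log units; within the scatter). Compound 3 `CC(C)Cc1ccc(C(C)c2nnc3n2N=C(c2ccc(C(F)(F)F)cc2)CS3)cc1` gives 6500 nM in this assay, the lowest of the three numbers, although its gap to compound 1 lies within the scatter and only its gap to compound 2 lies beyond it.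

Compound 4 `CC(C)Cc1ccc(C(C)c2nnc3n2N=C(c2ccccc2)CS3)cc1` departs from compound 3 by a single change: hydrogen in place of trifluoromethyl on an aromatic carbon. Among the measured compounds shown here, no measured pair shows exactly this change. For the measured compounds named here, the only measured step, from compound 1 to compound 2, also swaps one substituent for another on an aromatic carbon of the aryl ring, and it stayed within the scatter. Going by the values given here, with that as the sole guide, no step beyond the scatter is expected here either. Compound 4 is therefore estimated to give about 8000 nM in this assay, with a likely range from 3000 nM to 20000 nM. The step this estimate means, a 1.2-fold higher number from compound 3 to compound 4 (0.09 log units; within the scatter), is expected to remain within the usual scatter.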

Compound 4, half-maximal inhibitory concentration: 7600 nM
For compound 4 the middle estimate is 1.1-fold (0.02 log units) above the measured one; low and high end bracket the measured number.
By their numbers in this assay, from the lowest: compounds 3, 4, 1 and 2 (each within the scatter of the next, the first and the last beyond it).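

Taking away the trifluoromethyl and leaving a plain phenyl in place of the 4-(trifluoromethyl)phenyl gives in this assay a 1.2-fold higher number from compound 3 to compound 4 (0.07 log units; within the scatter), so the two compounds cannot be told apart on this read-out. The earlier step had only exchanged one substituent for another on this aromatic carbon and on a different version of the core, whereas this one shows that, with the rest of compound 3 kept, a group of 4 heavy atoms can go entirely and be replaced by hydrogen without a step beyond the scatter. Nothing here explains why this position tolerates the loss, as no supporting evidence bears on the result.

What the compounds shown leave open is whether an amine, a carboxylic acid or a longer chain such as a butoxy group on this aromatic carbon would give a step beyond the scatter in either direction. They also leave open whether methyl or nitro at this carbon would behave the same way on the core of compound 3 as they do on the core of compound 1.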